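Methylating the Amide Nitrogen: an Expectation for Compound 4

A few compounds are considered here, and "the series" means these few. Any claim that something is new, unique, unknown or untested is made for them only; others in the source may bear on it.

Measured so far:
Compound 1, `CNC(=O)/C=C1\CCc2ccc(Br)cc21`, in a functional assay on the whole organism with Rattus norvegicus as the target, at a dose of 20 mg/kg by the oral route (a higher number here means more inhibition at the dose given (going by the name of the read-out), a lower number less inhibition), gives 44%.
Compound 2, `NC(=O)/C=C1\CCc2cc(Cl)ccc21`, in this assay gives 30%.
Compound 3, `NC(=O)/C=C1\CCc2ccc(Br)cc21`, in this assay gives 38%.

Compounds 1 and 3 share one core; compound 2 carries a different one, and the difference between the two cores is not broken down here. From compound 3 to compound 1 the change is methyl in place of hydrogen on an amide-type nitrogen, and in this assay the step was a number 6 percentage points higher from compound 3 to compound 1 (within the scatter). Compound 2 stands lowest of the three, within the scatter of compound 3 but beyond it against compound 1.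

Compound 4, `CNC(=O)/C=C1\CCc2cc(Cl)ccc21`, has not yet been measured. It differs from compound 2 by methyl in place of hydrogen on an amide-type nitrogen, the same change, at the same place, as from compound 3 to compound 1. The step from compound 2 to compound 4 in this assay is therefore expected to be a number 6 percentage points higher from compound 2 to compound 4 (within the scatter), resting on the earlier step of a number 6 percentage points higher from compound 3 to compound 1 (within the scatter). Compound 4 is thus estimated at 36%, expected to fall between 22% and 50%.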

Compound 4, a percentage reported as inhibition, in the whole organism at one dose (the size of the read-out at that dose, not a potency): 40%
Compound 4: middle estimate off by 4 percentage points, on the low side; the measured number falls inside the stated range.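

In this assay the change of hydrogen to methyl on the amide-type nitrogen reads a number 10 percentage points higher from compound 2 to compound 4 (within the scatter) on the second core. Set beside the earlier step, it shows that the change behaves alike on both cores: the same change on two cores in this assay, a number 6 percentage points higher (within the scatter) from compound 3 to compound 1 and a number 10 percentage points higher (within the scatter) from compound 2 to compound 4, 4 percentage points apart, within the scatter of two such steps. Each step on its own lies within the scatter, so the pair does not show that the methyl raises inhibition at all, and two cores cannot speak for every core in the series.

Only hydrogen and methyl appear on this nitrogen among the compounds shown. As far as these compounds go, whether a longer chain such as ethyl would fit the same picture stays open, as does the result of a carboxylic acid in place of the carbamoyl group.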